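Moving bromine from 2-bromophenyl to 4-bromophenyl: working notes

This account rests on a few compounds, and the source may have more. Where it says the series, first, only, none or still open, it means among the compounds named here.

Measured so far in an ADME assay on NIH3T3 cells (Mus musculus) for cytotoxicity, with a stated time of 72 h; on this read-out higher numbers stand for weaker inhibition and lower numbers for stronger inhibition:
- compound 1 `OC[C@H]1O[C@@H](n2cnc3c(NCc4cccc(F)c4)ncnc32)[C@H](O)[C@@H]1O` gives 84000 nM
- compound 2 `OC[C@H]1O[C@@H](n2cnc3c(NCc4ccc(F)cc4)ncnc32)[C@H](O)[C@@H]1O` gives 44300 nM
- compound 3 `OC[C@H]1O[C@@H](n2cnc3c(NCc4ccccc4Br)ncnc32)[C@H](O)[C@@H]1O` gives > 166000 nM as a limit of the assay, not a number

Among the compounds with values here, compound 3 has no exact position in this assay and rests at the limit of > 166000 nM in this assay, at which 1 of the 3 values shown sits, as its only reading. It is the starting point for compound 4 `OC[C@H]1O[C@@H](n2cnc3c(NCc4ccc(Br)cc4)ncnc32)[C@H](O)[C@@H]1O`, which is not yet measured. The change is 4-bromophenyl in place of 2-bromophenyl on a saturated chain carbon bound to a nitrogen on an aromatic ring for the two structures.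

Within the data shown here, no measured pair moves the bromine alone, so the evidence is indirect. The closest guide is an at least 3.7-fold higher number from compound 2 to compound 3 (0.57 log units; beyond the scatter) in the comparison of 4-fluorophenyl with 2-bromophenyl. A further floor comes from an at least 1.9-fold higher number from compound 1 to compound 3 (0.29 log units; that floor lies within the scatter) for the 3-fluorophenyl comparison. Moving the fluorine gives a 1.9-fold lower number from compound 1 to compound 2 (0.28 log units; within the scatter) as a smaller guide. Read in reverse, the step in an at least 3.7-fold higher number from compound 2 to compound 3 (0.57 log units; beyond the scatter) suggests that compound 4 should fall on the lower-number side of the limit and close to the fluorinated compounds. The expected step is an at least 3.3-fold lower number from compound 3 to compound 4 (0.52 log units; beyond the scatter) in the direction of a lower number. Compound 4 is expected near 50000 nM with a range from 20000 nM to 125000 nM as the estimate.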

Compound 4, half-maximal inhibitory concentration: > 166000 nM
Compound 4 gave a limit, no number (the forecaster's own chance of this, stated with the estimate: 15%); at least 3.3-fold (0.52 log units) between middle value and limit.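

In this assay, bromine gives a limit of the assay, not a number, at both places tested, so moving it from 2-bromophenyl to 4-bromophenyl does not bring the reading into the measurable range, and the steps that rest on two limits cannot be read. Bromo in place of fluoro on an aromatic carbon, a swap the earlier compounds did not offer on its own, gives an at least 3.7-fold higher number from compound 2 to compound 4 (0.57 log units; beyond the scatter), while the comparison with the 3-fluorophenyl compound gives only an at least 1.9-fold higher number from compound 1 to compound 4 (0.29 log units; that floor lies within the scatter). Within these four compounds the split now follows the halogen and not its place on the ring, with no compound going against it, the two fluoro compounds giving numbers and the two bromo compounds sharing one limit: the limit of > 166000 nM in this assay, at which 2 of the 4 values shown sit.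

Going by these compounds, how far compound 3 and compound 4 lie past that limit stays open, so no order can be given for the two bromine placements. Also open, on these data alone, is whether 4-chlorophenyl, or a carboxylic acid in place of the halogen, would return a number in this assay and so show how far the split extends.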